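Notes on a small aryl ether series in rat oral toxicity

The source may hold more compounds than are shown below. What is called first, only, known or untested is meant among the compounds shown, and "the series" means these compounds.

Measured so far:
compound 1, `COc1ccc(OCC2=NCCO2)cc1`: in a toxicity assay on the whole organism with Rattus norvegicus as the target, at a dose of 400 mg/kg by the oral route (a lower number here means a weaker effect, a higher number a stronger effect of the compound at the dose given), compound 1 gives 90%
compound 2, `Clc1ccc(OCC2=NCCO2)cc1`: in this assay compound 2 gives 90%
compound 3, `Brc1ccccc1OCC1=NCCO1`: in this assay compound 3 gives 100%

On the numbers shown, compound 3 carries the top figure of the three, but compound 1 and compound 2 each sit within the scatter of it, so no order among them is claimed. Compound 4 `Cc1ccccc1OCC1=NCCO1` differs from compound 3 by methyl in place of bromo on an aromatic carbon. Among the compounds with values here, the only measured single step, no change at the digits printed from compound 1 to compound 2 (within the scatter), concerns a different change at a different place and bears on this one only loosely; no exchange of bromo for methyl has been measured. With three values lying close together and that flat step, no move beyond the scatter is expected for compound 4 in this assay, that is a number 10 percentage points lower from compound 3 to compound 4 (within the scatter). Compound 4 is therefore estimated at 90%, with a range from 70% to 100%.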

Compound 4, a percentage reported as activity, at one dose (the size of the read-out at that dose, not a potency): 100%
Compound 4: the middle estimate sits 10 percentage points below what was measured; low and high end bracket the measured number.
By their numbers in this assay, from the lowest: compounds 1, 2, 3 and 4 (each within the scatter of the next).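

In this assay, methyl in place of bromo on an aromatic carbon, ortho to a group of 7 heavy atoms, gives no change at the digits printed from compound 3 to compound 4 (within the scatter). Within the data shown here, this is the first measured exchange at this place, and it adds a second flat step to the one seen at a different place. No measured data here bear on the reason for this flat step.

Still open, from the compounds shown here alone, is whether an amine or a carboxylic acid at this place would leave the read-out equally flat. Going by these compounds, a longer chain in place of methyl also remains open.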